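Purine acetamides in the tail flick test: notes

A few compounds are considered here, and "the series" means these few. Any claim that something is new, unique, unknown or untested is made for them only; others in the source may bear on it.

Measured so far:
compound 1, `N=C(N)NCCC[C@H](NC(=O)CN(c1nc(Cl)nc2[nH]cnc12)C1CC1)C(=O)O`: 7.19%
compound 2, `O=C(OCc1ccccc1)[C@@H]1CCCN1C(=O)CN(c1nc(Cl)nc2[nH]cnc12)C1CC1`: 31.1%
compound 3, `NC(=O)C[C@H](NC(=O)CN(c1ncnc2c1ncn2C1CCCCO1)C1CC1)C(=O)OCc1ccccc1`: 21.7%

All three numbers come from a functional assay on the whole organism (Tail, strain ICR) with Mus musculus as the target, in the tail flick test, with a stated time of 150 min, at a dose of 25 umol/kg by the oral route; a lower number here means a weaker effect, a higher number a stronger effect of the compound at the dose given. Compound 1 stands lowest of the three. Compound 3 lies above it by a margin beyond the scatter, and compound 2 lies further above still, also beyond the scatter. Within the data shown here, both compound 2 and compound 3 differ from compound 1 in more than one place, so neither pair isolates a single structural change, and no step between measured compounds can be read off directly.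

Compound 4, `CC(C)[C@H](NC(=O)CN(c1nc(Cl)nc2[nH]cnc12)C1CC1)C(=O)O`, is not yet measured. It differs from compound 1 by a group of 3 heavy atoms (3 carbon; no ring) in place of a group of 7 heavy atoms (4 carbon, 3 nitrogen; no ring), on a saturated chain carbon bound to an amide-type nitrogen and a carbonyl carbon. Among the measured compounds shown here, nothing in the measured set tests this particular exchange on its own; the only guidance is that the whole series sits at low to moderate activity and that compound 1 is at the bottom of it.

The step from compound 1 to compound 4 is expected to be small and upward, most likely within the scatter: a number 6.8 percentage points higher from compound 1 to compound 4 (within the scatter). Compound 4 is therefore expected to give 14%, with a range from 2% to 32%.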

Compound 4, a percentage reported as activity, at one dose (the size of the read-out at that dose, not a potency): 7.86%
Compound 4: middle estimate off by 6.1 percentage points, on the high side; low and high end bracket the measured number.
By their numbers in this assay, from the lowest: compounds 1 and 4 (each within the scatter of the next); then compounds 3 and 2 (each within the scatter of the next).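

Among these compounds, on the saturated chain carbon bound to an amide-type nitrogen and a carbonyl carbon, isopropyl in place of the group of 7 heavy atoms (4 carbon, 3 nitrogen) gives a number 0.7 percentage points higher from compound 1 to compound 4 (within the scatter) in this assay and this is the only comparison that isolates one place. At this dose and time, the read-out therefore does not separate the two side chains, although the group that leaves carries 3 hydrogen-bond donors and a double bond outside aromatic rings and isopropyl carries no hydrogen-bond donors and no such double bond. No measurement at hand explains this outcome.

Still open, on these data alone, is whether a primary amine on a shorter chain, a longer straight alkyl chain or a phenyl ring at the same carbon would give a number clearly apart from those of compound 1 and compound 4. Also open, as far as these compounds go, is whether the exchange of this side chain reads the same once the carboxylic acid of compound 1 is replaced by a benzyl ester, as a single change on an otherwise unchanged structure.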